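The compounds below may be only part of what the source reports. "The series", "measured", "known", "first", "only" and "open" are said of these compounds alone.

Three compounds have been measured in an ADME assay on MT4 cells (Homo sapiens) for cytotoxicity, read by MTT assay, with a stated time of 4 days; on this read-out higher numbers stand for lower toxicity in this test and lower numbers for higher toxicity in this test:

compound 1, `COc1ccc(/C=C/C(=O)c2cc(NC(C)=O)ccc2O)cc1`, with 38700 nM
compound 2, `CC(=O)Nc1ccc(O)c(C(=O)/C=C/c2ccc(F)cc2)c1`, with 41100 nM
compound 3, `COc1ccc(-c2oc3ccc(N)cc3c(=O)c2O)cc1`, with 239000 nM

Compound 1 and compound 2 differ in one place only: fluoro in place of methoxy on an aromatic carbon. In this assay that change made a 1.1-fold higher number from compound 1 to compound 2 (0.03 log units; within the scatter), so the two numbers cannot be told apart.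

Compound 3 is built on a different core from compound 1, and the difference between the two cores is not broken down here. Its number in this assay is the highest of the three, and its distance from both compound 1 and compound 2 lies beyond the usual scatter of repeated measurements.

Compound 4, `Nc1ccc2oc(-c3ccc(F)cc3)c(O)c(=O)c2c1`, is not yet measured. It differs from compound 3 by fluoro in place of methoxy on an aromatic carbon. This is the same change that leads from compound 1 to compound 2, made at the same kind of place on the ring, and among the compounds shown it occurs twice in all.

For compound 4 in this assay the expected step is a 1.0-fold higher number from compound 3 to compound 4 (0.02 log units; within the scatter), which rests on the earlier change from compound 1 to compound 2 having given a 1.1-fold higher number from compound 1 to compound 2 (0.03 log units; within the scatter), a step within the scatter. Going by the values given here, since that is the only measured instance of the change, the expectation for compound 4 is that its number stays close to the number of compound 3, estimated at 250000 nM, with the likely range running from 120000 nM to 500000 nM.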

Compound 4, half-maximal cytotoxic concentration: 92600 nM
Estimate against measurement, compound 4: 2.7-fold (0.43 log units) above, and the stated range ends above it.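

In this assay, fluoro in place of methoxy on an aromatic carbon gave a 2.6-fold lower number from compound 3 to compound 4 (0.41 log units; beyond the scatter), so on the core of compound 3 the change moved the number towards higher toxicity in this test, while on the core of compound 1 it gave a 1.1-fold higher number from compound 1 to compound 2 (0.03 log units; within the scatter). The change therefore did not carry over from one core to the other with the same size, and the result on one core would not have been a safe guide to the result on the other: the same change on two cores in this assay, a 1.1-fold higher number (0.03 log units; within the scatter) from compound 1 to compound 2 and a 2.6-fold lower number (0.41 log units; beyond the scatter) from compound 3 to compound 4, 2.7-fold (0.44 log units) apart, beyond the scatter of two such steps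

This shows that in this series the step depends on the core that carries it, but with a single pair on each core it does not show which feature of the two cores sets them apart, nor whether the gap would hold for further pairs on the same cores.

The compounds shown leave open whether a different group on that aromatic carbon, such as chloro, methyl or trifluoromethyl, would also separate the two cores in this way. They also leave open whether the step on the core of compound 3 would stay the same if the amine on that core were replaced by a longer chain or a carboxylic acid.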